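This account rests on a few compounds, and the source may have more. Where it says the series, first, only, none or still open, it means among the compounds named here.

Measured compounds:
- compound 1 `CCCS(=O)(=O)Nc1ccc(F)c(C(=O)c2n[nH]c3ncc(-c4ccccc4C)cc23)c1F`: 7% in an assay for binding affinity to dual specificity mitogen-activated protein kinase kinase 4 (Homo sapiens), read by KINOMEscan, tested at 100 nM; a higher number here means a weaker effect of the compound at the concentration tested, a lower number a stronger effect
- compound 2 `CCCS(=O)(=O)Nc1ccc(F)c(C(=O)c2n[nH]c3ncc(-c4ccccc4OC)cc23)c1F`: 1.9%
- compound 3 `CCCS(=O)(=O)Nc1ccc(F)c(C(=O)c2n[nH]c3ncc(-c4cccc(N)c4)cc23)c1F`: 1.6%

Where compound 3 stands is shown by two steps: a number 5.4 percentage points lower from compound 1 to compound 3 (within the scatter) and a number 0.3 percentage points lower from compound 2 to compound 3 (within the scatter). All three numbers therefore sit together within the scatter. Compound 4 `CCCS(=O)(=O)Nc1ccc(F)c(C(=O)c2n[nH]c3ncc(-c4cccc(C(F)(F)F)c4)cc23)c1F` has not yet been measured. It differs from compound 3 in one place: trifluoromethyl in place of amino on an aromatic carbon. The two measured steps that bear on this change both altered the substituted phenyl, and neither moved the read-out beyond the scatter. Compound 4 is therefore expected to show a step of a number 2.4 percentage points higher from compound 3 to compound 4 (within the scatter) in this assay, nothing beyond the scatter. The estimate for compound 4 is 4%, within a range from 0.5% to 20%.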

Compound 4, a percentage reported as activity, at one concentration (the size of the read-out at that concentration, not a potency): 57%
The estimate for compound 4 lay 53 percentage points below the measured number; the measured number lies above the stated range.
By their numbers in this assay, from the lowest: compounds 3, 2 and 1 (each within the scatter of the next); then compound 4.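

In this assay, the earlier changes to the substituted phenyl left the read-out within the scatter, but this position proves sensitive to what it carries: trifluoromethyl in place of amino gives a number 55.4 percentage points higher from compound 3 to compound 4 (beyond the scatter). The 3-(trifluoromethyl)phenyl group also stands apart from the other two aryl groups, with a number 55.1 percentage points higher from compound 2 to compound 4 (beyond the scatter) and a number 50 percentage points higher from compound 1 to compound 4 (beyond the scatter). Nothing shown here accounts for this large step. Going by these compounds, it remains open whether only trifluoromethyl has this effect, or whether a methyl group, a nitrile or a carboxylic acid on the same aromatic carbon would behave likewise.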